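This account rests on a few compounds, and the source may have more. Where it says the series, first, only, none or still open, it means among the compounds named here.

In a functional assay on B16-F10 cells (Mus musculus) for cytotoxicity (on this read-out higher numbers stand for weaker inhibition and lower numbers for stronger inhibition), three compounds sharing one core have been measured. Compound 1 (`O=c1oc2ccccc2c2nc3c(ccc4cc[nH]c43)c(-c3cccnc3Cl)c12`) gives 70700 nM, compound 2 (`O=c1oc2ccccc2c2nc3c(ccc4cc[nH]c43)c(-c3cccc4ccccc34)c12`) gives 70700 nM, and compound 3 (`O=c1oc2ccccc2c2nc3c(ccc4cc[nH]c43)c(-c3cccc(Br)c3)c12`) gives 70700 nM, so compound 3 stands level with the other two. Compound 4 (`O=c1oc2ccccc2c2nc3c(ccc4cc[nH]c43)c(-c3c(Cl)cccc3Cl)c12`) keeps the core of compound 3 and differs in one group: 2,6-dichlorophenyl in place of 3-bromophenyl on an aromatic carbon. The 2,6-dichlorophenyl takes the place of the 3-bromophenyl on the aromatic carbon opposite the ring nitrogen.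

The measured steps that bear on this change are exchanges of the group on that same carbon: no change at the digits printed from compound 1 to compound 3 (within the scatter), no change at the digits printed from compound 1 to compound 2 (within the scatter) and no change at the digits printed from compound 2 to compound 3 (within the scatter). All three stay within the scatter. Within the data shown here, no measured compound carries the 2,6-dichlorophenyl group, so the data do not test it directly. Even so, with three different groups giving no step at all, no step beyond the scatter is expected in this assay, and no direction is favoured. The expectation is a 1.1-fold lower number from compound 3 to compound 4 (0.04 log units; within the scatter), an estimated step that stays small. For compound 4 the estimated value is 65000 nM, with an expected range from 30000 nM to 100000 nM.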

Compound 4, half-maximal inhibitory concentration: 70700 nM
Compound 4: middle estimate off by 1.1-fold (0.04 log units), on the low side; the range from low to high includes it.
By their numbers in this assay, from the lowest: compounds 1, 2, 3 and 4 (each within the scatter of the next).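

In this assay the 2,6-dichlorophenyl group is a fourth group on the aromatic carbon opposite the ring nitrogen, and the result reads no change at the digits printed from compound 3 to compound 4 (within the scatter) and no change at the digits printed from compound 2 to compound 4 (within the scatter) and no change at the digits printed from compound 1 to compound 4 (within the scatter) at this position. This extends the flat picture to a group with two chlorine atoms in place of one bromine, so that all four groups on this carbon now share one printed number. Nothing available explains why the number stays the same.

All four groups are six-membered or fused aromatic rings, so the compounds shown leave open whether an amine, a carboxylic acid or a plain alkyl chain on this carbon would move the number. As far as these compounds go, whether a bare hydrogen there would do so also stays open.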